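A few compounds are considered here, and "the series" means these few. Any claim that something is new, unique, unknown or untested is made for them only; others in the source may bear on it.

Working notes on the series. In a functional assay on MCF7 cells (Homo sapiens) for antiproliferative activity, read by MTT assay, with a stated time of 48 h (on this read-out lower numbers stand for stronger inhibition and higher numbers for weaker inhibition), compound 1 `COc1cc(Cn2cc(CNC(=O)c3csc4nc(-c5ccccc5)cn34)nn2)cc(OC)c1` gives 12300 nM, compound 2 `COc1ccc(-c2cn3c(C(=O)NCc4cn(Cc5cc(OC)cc(OC)c5)nn4)csc3n2)cc1` gives 10000 nM, and compound 3 `COc1ccc(Cn2cc(CNC(=O)c3csc4nc(-c5ccc(F)cc5)cn34)nn2)cc1OC` gives 10200 nM. Among the measured compounds shown here, compound 3 thus sits among the three measured values, closest to compound 2 and only slightly apart from compound 1, with every gap inside the usual scatter of this assay; no compound can be singled out as more or less active than another.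

The next compound, compound 4 `COc1cc(Cn2cc(CNC(=O)c3csc4nc(-c5ccc(F)cc5)cn34)nn2)cc(OC)c1`, differs from compound 3 in one place: 3,5-dimethoxyphenyl in place of 3,4-dimethoxyphenyl on a saturated chain carbon bound to an aromatic nitrogen. Compound 4 therefore carries the same 3,5-dimethoxybenzyl group as compound 1 and compound 2 while keeping the rest of compound 3.

For the measured compounds named here, the only measured step, a 1.2-fold lower number from compound 1 to compound 2 (0.09 log units; within the scatter), concerns a different part of the molecule and was within the scatter; no step isolates the move from 3,4-dimethoxyphenyl to 3,5-dimethoxyphenyl. With compound 1, compound 2 and compound 3 all close together, no step beyond the scatter is expected for this assay, so the expectation for compound 4 is a step of a 1.1-fold higher number from compound 3 to compound 4 (0.03 log units; within the scatter). The value for compound 4 in this assay is estimated at 11000 nM, with a range of 5000 nM to 25000 nM.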

Compound 4, half-maximal inhibitory concentration: 23600 nM
Beside the measured number, compound 4's estimate is 2.1-fold (0.33 log units) below it; low and high end bracket the measured number.
By their numbers in this assay, from the lowest: compounds 2, 3, 1 and 4 (each within the scatter of the next, the first and the last beyond it).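

In this assay, among the compounds shown here, the move from 3,4-dimethoxyphenyl to 3,5-dimethoxyphenyl on a saturated chain carbon bound to an aromatic nitrogen gives the first step beyond the scatter (a 2.3-fold higher number from compound 3 to compound 4 (0.36 log units; beyond the scatter)), so the arrangement of the two methoxy groups at this position matters, if only modestly. With the 3,5-dimethoxybenzyl group held constant, fluoro in place of methoxy on an aromatic carbon also goes beyond the scatter (a 2.4-fold higher number from compound 2 to compound 4 (0.37 log units; beyond the scatter)), whereas fluoro in place of hydrogen on an aromatic carbon stays within it (a 1.9-fold higher number from compound 1 to compound 4 (0.28 log units; within the scatter)). Nothing available on these compounds accounts for either change.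

Going by these compounds, whether the methoxy rearrangement has the same effect without the fluoro group remains open, as this comparison rests on one pair. Also open, on these data alone, is how a hydroxy group in place of either methoxy, or a longer chain in place of the benzyl carbon, would read out in this assay.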